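The source may report more compounds than this note shows. Statements on the series, on what has been measured and on what is new or still open speak of the compounds shown alone.

In a functional assay on Huh-7 cells (Homo sapiens) for cytotoxicity, read by MTT assay, with a stated time of 72 h (on this read-out lower numbers stand for higher toxicity in this test and higher numbers for lower toxicity in this test), three compounds sharing a closely related core have been measured so far. Compound 1 `CS(=O)(=O)N1CCC2(CC1)OOC1(CCN(S(C)(=O)=O)CC1)OO2` gives > 100 ug/mL as its result, which is a limit of the assay and not a number. Compound 2 `CCS(=O)(=O)N1CCC2(CC1)OOC1(CCCCC1)OO2` gives > 100 ug/mL as its result, again a limit. Compound 3 `CCCS(=O)(=O)N1CCC2(CC1)OOC1(CCCCCC1)OO2` gives > 100 ug/mL as its result, also a limit. Compound 2 therefore has no exact value and stands with the others, as the summary shows: the limit of > 100 ug/mL in this assay, at which 3 of the 3 values shown sit.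

Compound 4 `O=S(=O)(CCCCl)N1CCC2(CC1)OOC1(CCCCC1)OO2` differs from compound 2 by one change, (chloromethyl in place of hydrogen on a saturated chain carbon, two bonds along the chain from a sulfonyl sulfur), which turns ethylsulfonyl into (3-chloropropyl)sulfonyl. For the measured compounds named here, no measured step between any two compounds is available as a guide. The expectation therefore rests on compound 2, with its > 100 ug/mL result, and no step beyond the scatter is expected in this assay in either direction. The estimated step of a number no higher from compound 2 to compound 4 (the limit leaves the size open) is accordingly small. For compound 4 the estimated value is 100 ug/mL, with an expected range from 45 ug/mL to 200 ug/mL, and a result reported only as a limit is also likely.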

Compound 4, half-maximal cytotoxic concentration: > 100 ug/mL
Compound 4: a limit, no number; the forecaster's own chance of this, stated with the estimate: 80%; the middle value lies on the limit itself.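

For the compounds shown here, no step from compound 2 to compound 4 can be read in this assay, since both results are limits and not numbers: the limit of > 100 ug/mL in this assay, at which 4 of the 4 values shown sit. The compounds shown leave open at what concentration each becomes toxic to these cells, and whether ethylsulfonyl and (3-chloropropyl)sulfonyl differ at all.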